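The source may report more compounds than this note shows. Statements on the series, on what has been measured and on what is new or still open speak of the compounds shown alone.

Of the compounds shown here, three built on a shared core have been tested in a functional assay on MCF7 cells (Homo sapiens) for inhibition, read by fluorescence, with a stated time of 72 h; a lower number here means a stronger inhibitor, a higher number a weaker inhibitor. Compound 1 `Cn1cnc2c(NC(=N)N)nc(N)nc21` reached only the limit of this assay, giving > 100000 nM. Compound 2 `CC(C)n1cnc2c(N)nc(N)nc21` likewise stopped at the limit, with > 100000 nM. Compound 3 `CC[C@@H](N)COc1nc(NC(=N)N)c2ncn(C(C)C)c2n1` also gave only a limit, > 100000 nM. Among the compounds with values here, compound 3 therefore stands nowhere distinct among the three: every number is a limit rather than a measured value, (the limit of > 100000 nM in this assay, at which 3 of the 3 values shown sit), and no step between two measured compounds can be drawn from them.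

Compound 4 `CC(C)n1cnc2c(NC(=N)N)nc(OC[C@H]3CCCN3)nc21` is the next compound, not yet measured in this assay. It differs from compound 3 in one place: pyrrolidin-2-yl in place of 1-aminopropyl on a saturated chain carbon bound to an oxygen on an aromatic ring. Every value shown is a limit; nothing measured tells how such a change shifts the number. The expectation is that the step from compound 3 to compound 4 shows no change beyond the scatter, a number no higher from compound 3 to compound 4 (the limit leaves the size open). Compound 4 is estimated at 100000 nM, between 20000 nM and 500000 nM, with a real chance that this assay again reports only a limit.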

Compound 4, half-maximal inhibitory concentration: > 100000 nM
Compound 4 gave a limit, no number; the forecaster's own chance of this, stated with the estimate: 75%; the middle value sits exactly at the limit.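

In this assay, within the data shown here, compound 4 gives > 100000 nM, which is a limit and not a number, so no step from compound 3 to compound 4 can be read. The compounds shown leave open which change of structure would yield a measured value at all: the limit of > 100000 nM in this assay, at which 4 of the 4 values shown sit.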